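The compounds below may be only part of what the source reports. "The series", "measured", "known", "first", "only" and "open" are said of these compounds alone.

Of the compounds shown here, three sharing one core have been measured in an assay on CHO cells with metabotropic glutamate receptor 5 (Homo sapiens) as the target; on this read-out lower numbers stand for an effect already at smaller amounts and higher numbers for an effect only at larger amounts of compound. Compound 1 `O=C(Nc1cc(-c2ccccc2)nn1-c1ccccc1)c1ccc(F)c(F)c1` gives 10 nM, compound 2 `O=C(Nc1cc(-c2ccccc2)nn1-c1ccccc1)c1ccccc1Cl` gives 2500 nM, and compound 3 `O=C(Nc1cc(-c2ccccc2)nn1-c1ccccc1)c1cccc(Cl)c1` gives 40 nM. Compound 3 thus stands second highest of the three numbers; a 4.0-fold higher number from compound 1 to compound 3 (0.60 log units; beyond the scatter), and a 63-fold lower number from compound 2 to compound 3 (1.80 log units; beyond the scatter). The move to compound 4 `O=C(Nc1cc(-c2ccccc2)nn1-c1ccccc1)c1ccccc1` is hydrogen in place of chloro on an aromatic carbon. Within the data shown here, no measured step removes a chloro outright, so the nearest guides are the replacements on the same carbonyl-bound ring: a 250-fold higher number from compound 1 to compound 2 (2.40 log units; beyond the scatter) was large, a 63-fold lower number from compound 2 to compound 3 (1.80 log units; beyond the scatter) was large, while a 4.0-fold higher number from compound 1 to compound 3 (0.60 log units; beyond the scatter) was modest. The two compounds bearing a 3-chloro or a 3,4-difluoro group, compound 1 and compound 3, give the two lowest numbers, whereas compound 2 with its 2-chlorophenyl gives the highest, but no bare benzoyl has been measured. Compound 4 is expected to give a moderately higher number than compound 3, a step of about a 3.0-fold higher number from compound 3 to compound 4 (0.48 log units; beyond the scatter). The estimate for compound 4 in this assay is 120 nM, with a range from 40 nM to 400 nM.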

Compound 4, half-maximal effective concentration: 40 nM
Compound 4: middle estimate off by 3.0-fold (0.48 log units), on the high side, and the stated range covers the measured number.
By their numbers in this assay, from the lowest: compound 1; then compounds 3 and 4 (each within the scatter of the next); then compound 2.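

In this assay, taking the chloro off this aromatic carbon gives no change at the digits printed from compound 3 to compound 4 (within the scatter), so at this place the 3-chlorophenyl and the plain phenyl cannot be told apart. The same exchange starting from the 2-chlorophenyl gives a 63-fold lower number from compound 2 to compound 4 (1.80 log units; beyond the scatter), which ties the high number of compound 2 to a chloro in that position on the ring, not to chloro as such. The 3,4-difluorophenyl still stands apart from the plain phenyl, with a 4.0-fold higher number from compound 1 to compound 4 (0.60 log units; beyond the scatter), and among these four compounds it is the only ring substitution that gives a lower number than the unsubstituted one.

Nothing given here offers a reason for these steps. What a methoxy group, an amine or a carboxylic acid would do on this aromatic carbon stays open, as does which of the two fluoro atoms of compound 1 accounts for its lower number.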